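The compounds below may be only part of what the source reports. "The series", "measured", "known", "first", "only" and "open" are said of these compounds alone.

Measured so far:
- Compound 1, `CC(C(=O)NCc1ccc(C(F)(F)F)cc1N1CCCCCC1)c1ccc(NS(C)(=O)=O)c(F)c1`: 1.6 nM
- Compound 2, `CC1CCN(c2cc(C(F)(F)F)ccc2CNC(=O)C(C)c2ccc(NS(C)(=O)=O)c(F)c2)CC1`: 0.9 nM

Among the compounds with values here, in an assay on CHO cells for antagonist activity at transient receptor potential cation channel subfamily V member 1 (Homo sapiens), read by FLIPR (a higher number here means a weaker inhibitor, a lower number a stronger inhibitor), compound 2 gives the lower of the two numbers, with compound 1 the only neighbour, and the step of a 1.8-fold lower number from compound 1 to compound 2 (0.25 log units; within the scatter) lies within the scatter, so neither compound can be called the stronger inhibitor on this evidence.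

Compound 3, `CC(C(=O)NCc1ccc(C(F)(F)F)cc1N1CCC(C)(C)CC1)c1ccc(NS(C)(=O)=O)c(F)c1`, has not yet been measured. It differs from compound 2 by methyl in place of hydrogen on a saturated ring carbon; the nitrogen-bearing ring is kept and only a second methyl is placed on the ring carbon that already carries one.

Within the data shown here, the only measured step, from compound 1 to compound 2, exchanged one saturated ring for another and stayed within the scatter. Among the measured compounds shown here, no measured pair shows what a further methyl on that ring carbon does. With nothing pointing either way, the step from compound 2 to compound 3 is expected to be a 1.3-fold higher number from compound 2 to compound 3 (0.12 log units; within the scatter), that is, no change beyond the scatter. Compound 3 is therefore estimated at 1.2 nM in this assay, with a range from 0.4 nM to 3.5 nM.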

Compound 3, inhibition constant: 1.3 nM
Compound 3: middle estimate off by 1.1-fold (0.03 log units), on the low side; the range from low to high includes it.
By their numbers in this assay, from the lowest: compounds 2, 3 and 1 (each within the scatter of the next).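

In this assay, a second methyl on the saturated ring carbon, three ring bonds from the ring nitrogen, gives a 1.4-fold higher number from compound 2 to compound 3 (0.16 log units; within the scatter), so on these compounds the groups 4,4-dimethylpiperidin-1-yl and 4-methylpiperidin-1-yl cannot be told apart. Replacing azepan-1-yl with 4,4-dimethylpiperidin-1-yl gives a 1.2-fold lower number from compound 1 to compound 3 (0.09 log units; within the scatter), which means that all three ring groups on this aromatic carbon now lie within the scatter of one another. No independent measurement is available that could explain this result.

The compounds shown leave open how a hydroxyl, a carboxylic acid or an amine on this same ring carbon would read in this assay. They also leave open what plain piperidin-1-yl, with no methyl, or morpholin-4-yl, with an oxygen in the ring, would give on the same aromatic carbon.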